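Swapping the sulfonate oxygen bridge for an amine link

This account rests on a few compounds, and the source may have more. Where it says the series, first, only, none or still open, it means among the compounds named here.

Measured so far:
compound 1 `Cc1ccccc1OS(=O)(=O)c1cccc(NC(=O)NCCCCl)c1` — 29000 nM
compound 2 `CCc1ccccc1OS(=O)(=O)c1cccc(NC(=O)NCCCCl)c1` — 24000 nM

Both compounds were tested in a functional assay on M21 cells (Homo sapiens) for cytotoxicity, read by sulforhodamine B assay, with a stated time of 48 h; a lower number here means a stronger inhibitor, a higher number a weaker inhibitor. Going by the values given here, compound 1 stands highest of the two numbers, but its only neighbour, compound 2, lies a 1.2-fold lower number from compound 1 to compound 2 (0.08 log units; within the scatter), so the two cannot be ranked against each other.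

Compound 3 `Cc1ccccc1NS(=O)(=O)c1cccc(NC(=O)NCCCCl)c1` is not yet measured. It differs from compound 1 in one place: (2-methylphenyl)amino in place of 2-methylphenoxy on a sulfonyl sulfur. Among the compounds with values here, no measured step touches the group on the sulfonyl sulfur; the single known step changes only the substituent on the other ring, and that step stays within the scatter. There is therefore nothing in these data to point to a stronger or weaker inhibitor, and a step of no clear size beyond the scatter is expected, a 1.3-fold lower number from compound 1 to compound 3 (0.12 log units; within the scatter). On that basis compound 3 is estimated at 22000 nM, within a range from 5000 nM to 90000 nM.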

Compound 3, half-maximal inhibitory concentration: 60000 nM
For compound 3 the middle estimate is 2.7-fold (0.44 log units) below the measured one, and the stated range covers the measured number.
By their numbers in this assay, from the lowest: compounds 2 and 1 (each within the scatter of the next); then compound 3.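

Going by these compounds alone, exchanging the 2-methylphenoxy group on the sulfonyl sulfur for (2-methylphenyl)amino gives a 2.1-fold higher number from compound 1 to compound 3 (0.32 log units; beyond the scatter) in this assay and so yields the first step in this short series to pass beyond the scatter. This position therefore responds to change, even though the step is modest: the aromatic ring and its methyl group stay, while the linking oxygen gives way to a nitrogen that carries a hydrogen-bond donor. Nothing measured here explains the rise in the number.

Still open, from the compounds shown here alone, is whether a methyl group on that linking nitrogen or a methylene link in its place would move the number further. It is also unknown whether the ethyl group of compound 2 would behave the same way with the amine link.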